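Allyl Ether on the Oxime Oxygen in a Dopamine Receptor Series

The compounds below may be only part of what the source reports. "The series", "measured", "known", "first", "only" and "open" are said of these compounds alone.

For the measured compounds named here, compound 3 `CC(C)O/N=C(\CCN1CCN(c2ccccn2)CC1)c1ccccc1` stands second highest of the three numbers so far in a functional assay on HEK293 cells with D(4) dopamine receptor (Homo sapiens) as the target, read by FLIPR (a lower number here means that less compound is needed, a higher number that more compound is needed for the effect), giving 164 nM. Compound 1 `O/N=C(\CCN1CCN(c2ccccn2)CC1)c1ccccc1` gives 4.4 nM and compound 2 `CCCO/N=C(\CCN1CCN(c2ccccn2)CC1)c1ccccc1` gives 320 nM. The steps of a 73-fold higher number from compound 1 to compound 2 (1.86 log units; beyond the scatter) and a 37-fold higher number from compound 1 to compound 3 (1.57 log units; beyond the scatter) were both large, while the step of a 2.0-fold lower number from compound 2 to compound 3 (0.29 log units; within the scatter) lay within the scatter. Compound 4 `C=CCO/N=C(\CCN1CCN(c2ccccn2)CC1)c1ccccc1` carries allyl in place of isopropyl on an oxygen. Only the comparison of the two substituted oxygens bears on this change, and because a 2.0-fold lower number from compound 2 to compound 3 (0.29 log units; within the scatter) was small, another group of the same size on this oxygen is expected to give a similar number. Compound 4 is therefore expected to show a step of a 1.4-fold higher number from compound 3 to compound 4 (0.15 log units; within the scatter) within the scatter. For compound 4 the estimate is 230 nM, ranging from 80 nM to 700 nM.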

Compound 4, half-maximal effective concentration: 350 nM
Beside the measured number, compound 4's estimate is 1.5-fold (0.18 log units) below it, and the stated range covers the measured number.
By their numbers in this assay, from the lowest: compound 1; then compounds 3, 2 and 4 (each within the scatter of the next, the first and the last beyond it).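

In this assay, allyl and isopropyl carry the same count of heavy atoms, yet a 2.1-fold higher number from compound 3 to compound 4 (0.33 log units; beyond the scatter) shows that exchanging them at this oxygen can move the number modestly. Between the two straight chains, a 1.1-fold higher number from compound 2 to compound 4 (0.04 log units; within the scatter) stays within the scatter, so the double bond does not separate allyl from propyl here. Allyl also stays far from the free oxygen of the first compound, with an 80-fold higher number from compound 1 to compound 4 (1.90 log units; beyond the scatter).

On these data alone, whether methyl, or a chain ending in an amine or a carboxylic acid, would bring the number back towards that of compound 1 stays open. Nothing available here accounts for these steps.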